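Aromatase inhibition series: fluoro in place of cyclohexylamino

This account rests on a few compounds, and the source may have more. Where it says the series, first, only, none or still open, it means among the compounds named here.

Compound 1 `N#Cc1ccc(Oc2cccnc2)cc1NC1CCCCC1` is tested in an assay on isolated protein for inhibition of Aromatase (Homo sapiens), read by fluorescence, tested at 1 uM (a higher number here means more inhibition at the concentration tested (going by the name of the read-out), a lower number less inhibition), and gives 33%. Compound 2 `N#Cc1ccc(-n2ccc3ccncc32)cc1Oc1ccccc1` in this assay gives 97%. Going by the values given here, of the two numbers so far, compound 1 stands lowest; the number of compound 2 lies above it by a gap beyond the usual scatter of repeated measurements. Among the compounds with values here, no step between two measured compounds that differ in a single place has been recorded, so no measured single-point change is available to set the size of the next step.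

Compound 3 `N#Cc1ccc(Oc2cccnc2)cc1F` is the next member and differs from compound 1 by fluoro in place of cyclohexylamino on an aromatic carbon. The group that leaves is the cyclohexylamino; the group that enters is a single fluorine with no ring, no hydrogen-bond donor and no hydrogen-bond acceptor, sitting on the aromatic carbon that is ortho to the cyano group and meta to the (pyridin-3-yl)oxy group.

Within the data shown here, with no measured step of this kind to lean on, the expected step from compound 1 to compound 3 is no change at the digits printed from compound 1 to compound 3 (within the scatter), within the scatter in either direction. In this assay compound 3 is estimated at 33%, expected between 8% and 62%.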

Compound 3, a percentage reported as inhibition, at one concentration (the size of the read-out at that concentration, not a potency): 15%
Estimate against measurement, compound 3: 18 percentage points above; low and high end bracket the measured number.
By their numbers in this assay, from the lowest: compound 3; then compound 1; then compound 2.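

In this assay, the series now has its first measured change at a single place, a number 18 percentage points lower from compound 1 to compound 3 (beyond the scatter). At this aromatic carbon, ortho to a cyano group and meta to a (pyridin-3-yl)oxy group, fluoro therefore does not match cyclohexylamino in the read-out, with compound 3 at 15%. The change removes the six-membered non-aromatic ring, the hydrogen-bond donor and the hydrogen-bond acceptor together, and no measurement available explains the lower number or separates the contributions of these features.

Open, from the compounds shown here alone, is whether the nitrogen or the carbon ring carries the higher number of compound 1: a plain amino group or a methylamino group at this carbon would retain the nitrogen without the ring, while a cyclohexyloxy group would retain the ring without the nitrogen. A hydrogen or a chloro group at the same carbon would also show whether fluoro itself differs from other small replacements on the core of compound 3.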